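From 3-bromophenyl to 4-bromophenyl in a growth assay

The source may hold more compounds than are shown below. What is called first, only, known or untested is meant among the compounds shown, and "the series" means these compounds.

Compound 1 `C=C(C)C(=O)N(Cc1cccc(Br)c1)C(=O)/C=C/c1cc(OC)c(OC)c(OC)c1` gives 5700 nM
Compound 2 `C=C(C)C(=O)N(Cc1ccccc1C)C(=O)/C=C/c1cc(OC)c(OC)c(OC)c1` gives 4200 nM

Within the data shown here, in a functional assay on DU-145 cells (Homo sapiens) for inhibition, read by WST assay, with a stated time of 48 h (on this read-out lower numbers stand for stronger inhibition of growth and higher numbers for weaker inhibition of growth), compound 1 gives 5700 nM and lies within the scatter of compound 2, the only other measured compound. Compound 3 `C=C(C)C(=O)N(Cc1ccc(Br)cc1)C(=O)/C=C/c1cc(OC)c(OC)c(OC)c1` has not been measured. It carries 4-bromophenyl in place of 3-bromophenyl on a saturated chain carbon bound to an amide-type nitrogen is the full difference. Among the measured compounds shown here, the only measured step at that place is a 1.4-fold lower number from compound 1 to compound 2 (0.13 log units; within the scatter) and it gives no sign of a large change. The estimated step of a 1.1-fold lower number from compound 1 to compound 3 (0.06 log units; within the scatter) is therefore expected to stay within the scatter. In this assay compound 3 is expected at 5000 nM with an estimated range of 2200 nM to 11000 nM as its likely span.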

Compound 3, concentration for 50% growth inhibition: 900 nM
Compound 3: the middle estimate sits 5.6-fold (0.74 log units) above what was measured; the measured number lies below the stated range.
By their numbers in this assay, from the lowest: compound 3; then compounds 2 and 1 (each within the scatter of the next).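

In this assay, 4-bromophenyl in place of 3-bromophenyl on a saturated chain carbon bound to an amide-type nitrogen gives a 6.3-fold lower number from compound 1 to compound 3 (0.80 log units; beyond the scatter), so two groups with the same atoms are not interchangeable at this place. 4-Bromophenyl in place of 2-methylphenyl gives a 4.7-fold lower number from compound 2 to compound 3 (0.67 log units; beyond the scatter), which shows a response at this place that the step between the two earlier compounds, within the scatter, did not show. Nothing measured here explains the difference. The compounds shown leave open whether a chlorine atom or a methoxy group in place of the bromine of 4-bromophenyl would keep the lower number.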